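The compounds below may be only part of what the source reports. "The series", "measured", "known", "first", "only" and "open" are said of these compounds alone.

Measured so far:
compound 1, `O=C(Nc1ccc(Cl)c(-c2nnc3c(Cl)cccn23)c1)c1ccccn1` — > 100000 nM
compound 2, `CS(=O)(=O)c1ccc(C(=O)Nc2ccc(Cl)c(-c3nnc4c(Cl)cccn34)c2)cc1` — > 100000 nM
compound 3, `Cc1cc(Cl)ccc1C(=O)Nc1ccc(Cl)c(-c2nnc3c(Cl)cccn23)c1` — 34300 nM

In a functional assay on MDA-MB-468 cells (Homo sapiens) for antiproliferative activity, read by MTT assay, with a stated time of 72 h (on this read-out lower numbers stand for stronger inhibition and higher numbers for weaker inhibition), compound 2 gives > 100000 nM, a limit of the assay rather than a number. Compound 1 likewise gives > 100000 nM, also a limit. Going by the values given here, compound 3 gives 34300 nM, the only numerical value of the three, and both an at least 2.9-fold lower number from compound 1 to compound 3 (0.46 log units; beyond the scatter) and an at least 2.9-fold lower number from compound 2 to compound 3 (0.46 log units; beyond the scatter) are at least modest drops. What those two steps can say is capped by the limit of > 100000 nM in this assay, at which 2 of the 3 values shown sit. Compound 4, `CS(=O)(=O)c1ccc(C(=O)Nc2ccc(Cl)c(-c3nnc4c(Cl)cccn34)c2)c(Cl)c1`, differs from compound 2 by chloro in place of hydrogen on an aromatic carbon, a change on the 4-(methylsulfonyl)phenyl ring. The step to compound 3 exchanged that whole ring for 4-chloro-2-methylphenyl; a single chloro is a smaller change. Compound 4 is therefore expected to stay near the limit, estimated at 80000 nM (range 20000 nM to 300000 nM), a step of an at least 1.2-fold lower number from compound 2 to compound 4 (0.09 log units; that floor lies within the scatter), not clearly beyond the scatter.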

Compound 4, half-maximal inhibitory concentration: > 100000 nM
Compound 4: only a limit was reported; the forecaster's own chance of this, stated with the estimate: 60%; at least 1.2-fold (0.09 log units) between middle value and limit.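

Compound 4 gives > 100000 nM, a limit and not a number; compound 2 also stands at a limit, and the step between them cannot be read. From the compounds shown here alone, whether chloro in place of hydrogen changes activity at all stays open.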